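The source may report more compounds than this note shows. Statements on the series, on what has been measured and on what is new or still open speak of the compounds shown alone.

Measured compounds in a functional assay on BJAB cells (Homo sapiens) for antiproliferative activity, with a stated time of 4 days; a lower number here means that less compound is needed, a higher number that more compound is needed for the effect:
- compound 1, `COc1cc(-c2c(C)nn(-c3nc(-c4ccc(Cl)c(Cl)c4)c(SC(C)C)s3)c2C(=O)O)cc(C(F)(F)F)c1`: 1380 nM
- compound 2, `Cc1nn(-c2nc(-c3ccc(Cl)c(Cl)c3)c(SC(C)C)s2)c(C(=O)O)c1-c1cncnc1`: 22000 nM
- compound 3, `Cc1c(-c2cc(Cl)cc(Cl)c2)c(C(=O)O)nn1-c1nc(-c2cccnc2)c(SC(C)C)s1`: "not active" (no number reported)

Compound 3 stands apart from the other two: in this assay compound 3 is reported as not active, with no single number, so it gives no anchor of its own. Compounds 1 and 2 share the core of compound 1 and differ only on the pyrazole-side aryl; the step of a 16-fold higher number from compound 1 to compound 2 (1.20 log units; beyond the scatter) is large, with the heteroaryl the weaker of the pair.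

Compound 4, `Cc1c(-c2cc(Cl)cc(Cl)c2)c(C(=O)O)nn1-c1nc(-c2cc(Cl)ccc2F)c(SC(C)C)s1`, is not yet measured. It differs from compound 3 in one place: 5-chloro-2-fluorophenyl in place of pyridin-3-yl on an aromatic carbon. For the measured compounds named here, no measured step covers this position; the only step recorded, from compound 1 to compound 2, concerns a different ring of the shared core, but it is of the same kind in reverse, a carbon-only aryl replacing a nitrogen-containing six-membered ring. On that loose analogy a lower number than compound 3 in this assay is expected, probably by a large margin, though compound 3 provides no number from which to count. Given that compound 1, the only carbon-only-aryl thiazole with a single value, gives 1380 nM, compound 4 is estimated at 3000 nM, with a range of 500 nM to 30000 nM.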

Compound 4, half-maximal effective concentration: 4800 nM
Estimate against measurement, compound 4: 1.6-fold (0.20 log units) below; the range from low to high includes it.
By their numbers in this assay, from the lowest: compound 1; then compound 4; then compound 2.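

For the compounds shown here, compound 3 is reported as not active in this assay and carries no number, so no step to compound 4 at 4800 nM can be read. The compounds shown leave open how far 5-chloro-2-fluorophenyl and pyridin-3-yl lie apart in number at this place on the shared core. No available evidence bears on this result.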